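The compounds below may be only part of what the source reports. "The series", "measured", "known", "first", "only" and "open" are said of these compounds alone.

Working notes on the series. The shared core carries a sulfonamide-linked aryl amide whose carbonyl substituent is varied. Compound 1 `COc1ccc(C(=O)NOCc2ccccc2)cc1S(=O)(=O)Nc1ccc2c(c1)cc(C)c(=O)n2C` gives 20% in a functional assay on THP-1 cells (Homo sapiens) for antiproliferative activity, tested at 20 uM; a higher number here means a stronger effect of the compound at the concentration tested, a lower number a weaker effect. Compound 2 `COc1ccc(C(=O)NO)cc1S(=O)(=O)Nc1ccc2c(c1)cc(C)c(=O)n2C` gives 32% in this assay. Among the compounds with values here, the only measured step, a number 12 percentage points higher from compound 1 to compound 2 (beyond the scatter), arises from hydrogen in place of benzyl on an oxygen. On the numbers available compound 2 stands highest of the two, with compound 1 the nearest at a value lower by that step.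

Compound 3 `COC(=O)c1ccc(OC)c(S(=O)(=O)Nc2ccc3c(c2)cc(C)c(=O)n3C)c1` is not yet measured in this assay. Its change from compound 2 is methoxy in place of hydroxyamino on a carbonyl carbon. The step of a number 12 percentage points higher from compound 1 to compound 2 (beyond the scatter) is the only one that bears on it, and only loosely: there the hydroxyamino group was kept and its oxygen substituent varied, whereas here the hydroxyamino group leaves entirely in favour of methoxy. Given that compound 2 with the free hydroxyamino group gave 32% and that compound 1 without the free hydroxyl gave the lower 20%, a downward step of modest size is expected, a number 17 percentage points lower from compound 2 to compound 3 (beyond the scatter), though it may sit within the scatter. Compound 3 is therefore estimated at 15%, with a range from 0% to 35%.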

Compound 3, a percentage reported as inhibition, at one concentration (the size of the read-out at that concentration, not a potency): 101%
Estimate against measurement, compound 3: 86 percentage points below, and the stated range ends below it.
By their numbers in this assay, from the lowest: compound 1; then compound 2; then compound 3.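

In this assay the carbonyl carbon turns out to be far more sensitive to change than the earlier pair indicated: methoxy in place of hydroxyamino gives a number 69 percentage points higher from compound 2 to compound 3 (beyond the scatter), and methoxy in place of (benzyloxy)amino gives a number 81 percentage points higher from compound 1 to compound 3 (beyond the scatter), both large steps, whereas changing only the oxygen substituent gave the modest a number 12 percentage points higher from compound 1 to compound 2 (beyond the scatter). Among these three compounds the highest read-out therefore belongs to compound 3, which has neither a free hydroxyamino group nor a substituted one, so that group is not required for the effect seen in this series. Nothing available explains the size of these steps.

Going by these compounds, whether the gain belongs to the methoxycarbonyl group itself or simply follows from the loss of the nitrogen stays open, and a carboxylic acid, a primary amide or an ethyl ester on the same carbonyl carbon would help separate these readings. Also open, on these data alone, is whether the stronger effect of compound 3 holds at other concentrations, as the read-out comes from a single concentration, and whether its effect extends beyond this one cell line.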